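Replacing an Aromatic Ring with Cyclohexyl on the Shared Core

The source may report more compounds than this note shows. Statements on the series, on what has been measured and on what is new or still open speak of the compounds shown alone.

Three compounds sharing one core carry different groups on an amine nitrogen. Compound 1 `O=C1C(Nc2cccc(Cl)c2)=CC(=O)c2c1nc1n2[C@H]2OC[C@@H](O)[C@H]2OC1` gives 7970 nM in a functional assay on HeLa cells (Homo sapiens) for inhibition, read by sulforhodamine B assay; on this read-out higher numbers stand for weaker inhibition and lower numbers for stronger inhibition. Compound 2 `Cc1ccc(NC2=CC(=O)c3c(nc4n3[C@H]3OC[C@@H](O)[C@H]3OC4)C2=O)cc1C` gives 4320 nM, and compound 3 `COc1ccccc1NC1=CC(=O)c2c(nc3n2[C@H]2OC[C@@H](O)[C@H]2OC3)C1=O` gives 7460 nM. Compound 3 stands second highest of the three numbers; its nearest neighbour is compound 1, its furthest compound 2, and both gaps lie within the scatter. Compound 4 `O=C1C(NC2CCCCC2)=CC(=O)c2c1nc1n2[C@H]2OC[C@@H](O)[C@H]2OC1` differs from compound 3 in one place: cyclohexyl in place of 2-methoxyphenyl on an amine nitrogen. The measured steps all exchange one aromatic group for another and were all within the scatter: a 1.8-fold lower number from compound 1 to compound 2 (0.27 log units; within the scatter), a 1.1-fold lower number from compound 1 to compound 3 (0.03 log units; within the scatter) and a 1.7-fold higher number from compound 2 to compound 3 (0.24 log units; within the scatter). Going by the values given here, none of them exchanges an aromatic ring for a non-aromatic one, so no measured step bears directly on this change. The expectation is therefore a step of a 1.2-fold higher number from compound 3 to compound 4 (0.08 log units; within the scatter), with no direction beyond the scatter supported. Compound 4 is estimated at 9000 nM, within a range from 3000 nM to 27000 nM.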

Compound 4, half-maximal inhibitory concentration: > 16000 nM
Compound 4 was reported as a limit; the forecaster's own chance of this, stated with the estimate: 10%; middle value at least 1.7-fold (0.24 log units) from the limit.
By their numbers in this assay, from the lowest: compounds 2, 3 and 1 (each within the scatter of the next). At a limit, above all of these: compound 4.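

In this assay compound 4 gives > 16000 nM, which is a limit of the assay and not an exact number. Going by these compounds alone, compound 4 brings the first exchange of an aromatic ring for a non-aromatic one on this amine nitrogen, and here the number moves beyond the scatter, as it did not among the aromatic groups: the data show an at least 2.1-fold higher number from compound 3 to compound 4 (0.33 log units; beyond the scatter) and an at least 3.7-fold higher number from compound 2 to compound 4 (0.56 log units; beyond the scatter). The comparison with 3-chlorophenyl is less firm, since it reads an at least 2.0-fold higher number from compound 1 to compound 4 (0.30 log units; that floor lies within the scatter), so this step alone does not establish weaker inhibition.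

From the compounds shown here alone, how far the true number of compound 4 lies past its limit remains open. Cyclohexyl is the only non-aromatic group shown, so it remains open whether a cyclopentyl group, an open chain such as n-hexyl or a benzyl group on this nitrogen would behave the same way.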